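From Compound 3 to Compound 4: A Bromophenyl Variant

The source may hold more compounds than are shown below. What is called first, only, known or untested is meant among the compounds shown, and "the series" means these compounds.

Three compounds have been measured in a functional assay on LoVo cells (Homo sapiens) for inhibition, read by MTT assay, with a stated time of 24 h; a lower number here means a stronger inhibitor, a higher number a weaker inhibitor:

Compound 1, `CC1(C)[C@H]2CC[C@]1(C)N(Cc1cn(-c3ccc(Cl)cc3)nn1)C(=O)C2`: 160 nM
Compound 2, `COc1ccccc1-n1cc(CN2C(=O)C[C@@H]3CC[C@@]2(C)C3(C)C)nn1`: 70 nM
Compound 3, `Cc1ccc(-n2cc(CN3C(=O)C[C@@H]4CC[C@@]3(C)C4(C)C)nn2)cc1`: 50 nM

Compound 3 gives the lowest number of the three, though the step of a 1.4-fold lower number from compound 2 to compound 3 (0.15 log units; within the scatter) lies within the scatter, so it cannot be set apart from compound 2; compound 1 lies further off, by a 3.2-fold lower number from compound 1 to compound 3 (0.51 log units; beyond the scatter). Compound 4, `CC1(C)[C@H]2CC[C@]1(C)N(Cc1cn(-c3cccc(Br)c3)nn1)C(=O)C2`, differs from compound 3 by 3-bromophenyl in place of 4-methylphenyl on an aromatic nitrogen. Going by the values given here, no measured step places a bromine on this phenyl, so the nearest guidance is a 3.2-fold lower number from compound 1 to compound 3 (0.51 log units; beyond the scatter), where the halogen-bearing phenyl carried the higher number, and a 2.3-fold lower number from compound 1 to compound 2 (0.36 log units; beyond the scatter). Compound 4 is therefore expected to give a modestly higher number than compound 3, a 2.4-fold higher number from compound 3 to compound 4 (0.38 log units; beyond the scatter). The estimate for compound 4 in this assay is 120 nM, between 50 nM and 300 nM.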

Compound 4, half-maximal inhibitory concentration: 30 nM
Beside the measured number, compound 4's estimate is 4.0-fold (0.60 log units) above it, outside the stated range (below it).
By their numbers in this assay, from the lowest: compounds 4, 3 and 2 (each within the scatter of the next, the first and the last beyond it); then compound 1.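

In this assay, a halogen on this phenyl does not by itself go with the higher number: the 3-bromophenyl of compound 4 cannot be set apart from the 4-methylphenyl, with a 1.7-fold lower number from compound 3 to compound 4 (0.22 log units; within the scatter), yet it differs clearly from the 2-methoxyphenyl, with a 2.3-fold lower number from compound 2 to compound 4 (0.37 log units; beyond the scatter), and from the 4-chlorophenyl, with a 5.3-fold lower number from compound 1 to compound 4 (0.73 log units; beyond the scatter). Nothing available explains these steps.

Going by these compounds, compound 1 and compound 4 differ in both the halogen and its place on the phenyl, so the contribution of each stays open. Also open, on these data alone, is how 3-chlorophenyl, or an amine or carboxylic acid on this phenyl, would read here.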